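This account rests on a few compounds, and the source may have more. Where it says the series, first, only, none or still open, it means among the compounds named here.

Working notes on the series. In a functional assay on DU-145 cells (Homo sapiens) for inhibition, read by trypan blue exclusion, with a stated time of 96 h (on this read-out lower numbers stand for stronger inhibition of growth and higher numbers for weaker inhibition of growth), compound 3 (`COc1ccccc1/C=C(/SCc1ccc(F)cc1)C(=O)c1ccc(Cl)cc1`) gives 10000 nM. Compound 1 (`COc1ccccc1/C=C(/SCc1ccc(Cl)c(Cl)c1)C(=O)c1ccc(Cl)cc1`) gives 10000 nM, and compound 2 (`COc1ccccc1/C=C(/SCc1ccc(F)cc1)C(=O)c1ccc(Br)cc1`) gives 10000 nM, so compound 3 stands level with both.

The next structure is compound 4 (`Cc1ccsc1/C=C(/SCc1ccc(F)cc1)C(=O)c1ccc(Cl)cc1`), reached through 3-methylthiophen-2-yl in place of 2-methoxyphenyl on a double-bonded chain carbon bound to a double-bonded chain carbon.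

Two measured steps are available, and both lie elsewhere in the molecule. Placing 4-fluorophenyl in place of 3,4-dichlorophenyl gives no change at the digits printed from compound 1 to compound 3 (within the scatter). Placing chloro in place of bromo gives no change at the digits printed from compound 2 to compound 3 (within the scatter). Neither step varies the group exchanged here, so the data give no direct size for this change and the range must stay wide. Among the compounds with values here, with no measured movement so far, no step beyond the scatter is expected in this assay. The estimated change is a 1.3-fold lower number from compound 3 to compound 4 (0.10 log units; within the scatter). For compound 4 the estimated value is 8000 nM, with an expected range from 2000 nM to 20000 nM.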

Compound 4, concentration for 50% growth inhibition: 50000 nM
Estimate against measurement, compound 4: 6.3-fold (0.80 log units) below, and the stated range ends below it.
By their numbers in this assay, from the lowest: compounds 1, 2 and 3 (each within the scatter of the next); then compound 4.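

Within the data shown here, the group on the double-bonded chain carbon is the first place where a change moves the read-out in this assay: 3-methylthiophen-2-yl in place of 2-methoxyphenyl gives a 5.0-fold higher number from compound 3 to compound 4 (0.70 log units; beyond the scatter) as a step beyond the scatter, whereas the two earlier steps, made elsewhere in the molecule, stayed within it. This position therefore responds to the exchange of a six-membered aromatic ring of carbon only for a five-membered aromatic ring with 1 hetero atom, although the counts of hydrogen-bond donors and acceptors stay the same and neither group carries a net charge. Nothing available bears on the reason for this rise.

The compounds shown leave open whether the rise follows from losing the methoxy group, from the ring exchange or from the methyl group on the new ring. Plain phenyl and unsubstituted thiophen-2-yl at this position would separate these three.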